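Clearance Expected to Stay High on Losing Hydroxymethyl

This account rests on a few compounds, and the source may have more. Where it says the series, first, only, none or still open, it means among the compounds named here.

Compound 1 `O=C(Nc1cccc(S(=O)(=O)C2CCCC2)c1)c1cccnc1N1CCC(F)(F)CC1` gives the limit > 399 mL.min-1.g-1 in an ADME assay on microsomes from liver (Mus musculus) for metabolic stability, read by LC-MS, with a stated time of 40 min, tested at 0.5 uM; a higher number here means faster removal of the compound, a lower number slower removal
Compound 2 `CC(C)(CO)S(=O)(=O)c1cccc(NC(=O)c2cccnc2N2CCC3(CC2)CC3)c1` gives the limit > 399 mL.min-1.g-1 in this assay
Compound 3 `CC(C)(C)NS(=O)(=O)c1cccc(NC(=O)c2ccc(NS(=O)(=O)C3(C)CC3)cc2N2CCC3(CC2)CC3)c1` gives 90 mL.min-1.g-1 in this assay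

At the limit of > 399 mL.min-1.g-1 in this assay, at which 2 of the 3 values shown sit, stands compound 2, with a limit and no number, and compound 1 shares that position. Among the measured compounds shown here, only compound 3 returns a number, and no measured step bears on the change followed here.

Compound 4 `CC(C)S(=O)(=O)c1cccc(NC(=O)c2cccnc2N2CCC3(CC2)CC3)c1` is reached from compound 2 by a single change hydrogen in place of hydroxymethyl on a saturated chain carbon bound to two saturated chain carbons and a sulfonyl sulfur in which hydrogen takes the place of hydroxymethyl on a saturated chain carbon bound to two saturated chain carbons and a sulfonyl sulfur. The same difference reads as 1-(hydroxymethyl)-1-methylethyl to isopropyl.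

The expected step in this assay is a step that the limit leaves unreadable from compound 2 to compound 4 and no change beyond the scatter is expected in either direction. This expectation rests on compound 2 and its limit of > 399 mL.min-1.g-1 as the sole reference point, so it remains a loose one. The assay may well report a limit again. For compound 4 the estimated value is 400 mL.min-1.g-1 with an expected range from 180 mL.min-1.g-1 to 800 mL.min-1.g-1 in this measurement.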

Compound 4, intrinsic clearance in microsomes: > 399 mL.min-1.g-1
Compound 4: a limit, no number; the forecaster's own chance of this, stated with the estimate: 55%; the middle value is on the limit's open side.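

Compound 2 and compound 4 both end at a limit rather than a number, so no step from one to the other can be read in this assay: the limit of > 399 mL.min-1.g-1 in this assay, at which 3 of the 4 values shown sit.

The compounds shown leave open whether hydrogen in place of hydroxymethyl changes intrinsic clearance in microsomes at all, and if it does, in which direction and by how much.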